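The source may hold more compounds than are shown below. What is called first, only, known or untested is meant among the compounds shown, and "the series" means these compounds.

Of the compounds shown here, three built on a shared core have been measured in a functional assay on MDA-MB-231 cells (Homo sapiens) for inhibition, read by sulforhodamine B assay, with a stated time of 48 h; a lower number here means a stronger inhibitor of growth, a higher number a weaker inhibitor of growth. Compound 1 `O=C(Nc1cccc(-n2cc(-c3ccncc3)c(-c3ccc(Cl)c(O)c3)n2)c1)Nc1ccc(Cl)c(Cl)c1` gives 1180 nM, compound 2 `COc1cc(-c2nn(-c3cccc(NC(=O)c4cccc(C(F)(F)F)c4)c3)cc2-c2ccncc2)ccc1Cl` gives 1240 nM, and compound 3 `O=C(Nc1cccc(-n2cc(-c3ccncc3)c(-c3ccc(Cl)c(O)c3)n2)c1)Nc1cc(C(F)(F)F)cc(C(F)(F)F)c1` gives 739 nM. Compound 2 has the highest of the three numbers, yet its nearest neighbour is compound 1, and even compound 3, the furthest from it, lies within the usual scatter, so no order among the three can be drawn from these numbers alone.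

Compound 4 `COc1cc(-c2nn(-c3cccc(NC(=O)Nc4ccc(Cl)c(C(F)(F)F)c4)c3)cc2-c2ccncc2)ccc1Cl` has not yet been measured. It differs from compound 2 in one place: (4-chloro-3-(trifluoromethyl)phenyl)amino in place of 3-(trifluoromethyl)phenyl on a carbonyl carbon. Compound 4 therefore carries at the carbonyl carbon an amino attachment of the kind found in compound 1 and compound 3, while keeping the methoxy and chloro substitution of compound 2 elsewhere. Among the measured compounds shown here, compound 3 gives 739 nM, while compound 2 gives 1240 nM, and that pair is the only guide to what an amino attachment with trifluoromethyl-bearing aryl might do here. On that ground a small step toward a lower number is expected, a 1.7-fold lower number from compound 2 to compound 4 (0.22 log units; within the scatter), a step that would itself stay within the scatter. Compound 4 is estimated to give about 750 nM in this assay, with a range from 300 nM to 1800 nM.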

Compound 4, concentration for 50% growth inhibition: 760 nM
For compound 4 the middle estimate is 1.0-fold (0.01 log units) below the measured one; measured number inside the range.
By their numbers in this assay, from the lowest: compounds 3, 4, 1 and 2 (each within the scatter of the next).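

Among the compounds shown here, the one-place change on the carbonyl carbon gives the first step in this assay that can be read directly between two compounds, a 1.6-fold lower number from compound 2 to compound 4 (0.21 log units; within the scatter), and that step lies within the scatter. At this place, therefore, (4-chloro-3-(trifluoromethyl)phenyl)amino cannot be told apart from 3-(trifluoromethyl)phenyl, even though the entering group adds a nitrogen, a chlorine and a hydrogen-bond donor. Nothing measured here bears on why the step has this size.

Because the change brings in the amino attachment and the chlorine together, the compounds shown do not separate what each contributes on its own, and a compound carrying only one of the two would be needed to do so. From the compounds shown here alone, it also remains open whether any group at this place can move the number beyond the scatter, such as a phenyl ring bearing a carboxylic acid or a dimethylamino group in place of the chlorine and trifluoromethyl, or a longer chain set on the carbonyl carbon in place of the aromatic ring.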